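Removing the chloro from the benzyl group of compound 3

The source may report more compounds than this note shows. Statements on the series, on what has been measured and on what is new or still open speak of the compounds shown alone.

Of the compounds shown here, three have been measured in a functional assay on SW 1116 cells (Homo sapiens) for antiproliferative activity, read by MTT assay, with a stated time of 48 h; a higher number here means a weaker inhibitor, a lower number a stronger inhibitor. Compound 1 `Fc1ccc(CSc2nnc(-c3cnccn3)s2)c(F)c1` gives 5180 nM, and compound 2 `Fc1cccc(F)c1CSc1nnc(-c2cnccn2)s1` gives 16800 nM. Compound 3 `Clc1ccccc1CSc1nnc(-c2cnccn2)n1-c1ccccc1` gives 18100 nM, the highest of the three numbers. The gap between compound 3 and compound 2 is within the scatter, so no order between them can be stated; the gap between compound 3 and compound 1 lies beyond the scatter, with compound 1 showing the lower number.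

Compound 4 `c1ccc(CSc2nnc(-c3cnccn3)n2-c2ccccc2)cc1` has not yet been measured. It differs from compound 3 in one place: hydrogen in place of chloro on an aromatic carbon. The same difference, read one bond further out, is 2-chlorophenyl to phenyl, or 2-chlorobenzyl to benzyl, on an aromatic carbon of a six-membered aromatic ring of carbon only.

Within the data shown here, no measured pair in this set isolates this change, so its effect is open. The account expects the step of a 1.2-fold higher number from compound 3 to compound 4 (0.08 log units; within the scatter) to stay near the scatter, with at most a small rise in the number. For compound 4 the estimate in this assay is 22000 nM, within a range of 8000 nM to 60000 nM.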

Compound 4, half-maximal inhibitory concentration: 15400 nM
Beside the measured number, compound 4's estimate is 1.4-fold (0.15 log units) above it; measured number inside the range.
By their numbers in this assay, from the lowest: compound 1; then compounds 4, 2 and 3 (each within the scatter of the next).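

In this assay, among these compounds, hydrogen in place of chloro gives a 1.2-fold lower number from compound 3 to compound 4 (0.07 log units; within the scatter), the first step in this set that isolates a single place. On this aromatic carbon, ortho to a large group, the chloro therefore makes no difference that can be read: the numbers of the 2-chlorobenzyl and benzyl compounds cannot be told apart, and the chloro is not needed to keep the number where it stands. Nothing available accounts for this result.

As far as these compounds go, whether a methoxy group or an amine at this same place would move the number beyond the scatter remains open. So does whether the same exchange of chloro for hydrogen would read the same way on the core of compound 1.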